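This account rests on a few compounds, and the source may have more. Where it says the series, first, only, none or still open, it means among the compounds named here.

Compound 3 `CCN(CC)c1ccc2cc(C(=O)c3ccc(N4CCN(C(C)=O)CC4)cc3)oc2c1` gives 25600 nM in a functional assay on SGC-7901 cells (Homo sapiens) for cytotoxicity, read by MTT assay, with a stated time of 48 h (on this read-out lower numbers stand for stronger inhibition and higher numbers for weaker inhibition), the highest of the three numbers seen. Compound 1 `CCN(CC)c1ccc2cc(C(=O)c3ccc(N4CCN(S(=O)(=O)c5ccc([N+](=O)[O-])cc5)CC4)cc3)oc2c1` gives 1860 nM, and compound 2 `CCN(CC)c1ccc2cc(C(=O)c3ccc(N4CCN(S(=O)(=O)c5ccc(C(F)(F)F)cc5)CC4)cc3)oc2c1` gives 170 nM. Compound 4 `CCN(CC)c1ccc2cc(C(=O)c3ccc(N4CCN(S(C)(=O)=O)CC4)cc3)oc2c1` differs from compound 3 by methylsulfonyl in place of acetyl on an amine nitrogen in a ring. The step that bears most on this is a 14-fold higher number from compound 1 to compound 3 (1.14 log units; beyond the scatter), which runs in the opposite direction and so suggests that a sulfonyl on that ring nitrogen is favoured over acetyl; the step of an 11-fold lower number from compound 1 to compound 2 (1.04 log units; beyond the scatter) concerns the aromatic substituent and touches this change only loosely. Neither step swaps acetyl for a sulfonyl without an aromatic ring, so a modest lowering is expected, a 3.2-fold lower number from compound 3 to compound 4 (0.51 log units; beyond the scatter). Compound 4 is therefore estimated at 8000 nM in this assay, within 2000 nM to 30000 nM.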

Compound 4, half-maximal inhibitory concentration: > 40000 nM
Compound 4: a limit, no number (the forecaster's own chance of this, stated with the estimate: 5%); at least 5.0-fold (0.69 log units) between middle value and limit.
By their numbers in this assay, from the lowest: compound 2; then compound 1; then compound 3. At a limit, above all of these: compound 4.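

In this assay compound 4 gives a limit and not a number: the limit of > 40000 nM in this assay, at which 1 of the 4 values shown sits. Methylsulfonyl in place of acetyl brings no lowering, an at least 1.5-fold higher number from compound 3 to compound 4 (0.19 log units; that floor lies within the scatter), though this floor leaves the true gap unsettled. A sulfonyl on the ring nitrogen therefore does not by itself carry the lower numbers, since replacing the substituted phenyl on the sulfonyl sulfur with methyl gives an at least 230-fold higher number from compound 2 to compound 4 (2.37 log units; beyond the scatter) and an at least 21-fold higher number from compound 1 to compound 4 (1.33 log units; beyond the scatter). The compounds shown leave open whether an unsubstituted phenyl or a longer alkyl chain on that sulfur would restore the lower numbers.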